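Urea series: pyrazolyl in place of methylpiperazinyl

The compounds below may be only part of what the source reports. "The series", "measured", "known", "first", "only" and "open" are said of these compounds alone.

Measured compounds:
compound 1 `Cc1cc(C)c(NC(=O)N(Cc2ccc(N3CCN(C)CC3)cc2)C2CCCCCC2)c(C)c1` — 57 nM
compound 2 `CSc1cc(C)nc(SC)c1NC(=O)N(Cc1ccccc1)Cc1cccc(-c2ccn(C)n2)c1` — 73 nM

In an assay on microsomes from intestine for inhibition of acyl-CoA:cholesterol acyltransferase (Oryctolagus cuniculus) (on this read-out higher numbers stand for weaker inhibition and lower numbers for stronger inhibition), compound 1 gives 57 nM. Compound 2, built on a different core with a methylpyrazolyl on the benzyl arm, gives 73 nM in this assay. Compound 1 holds the lowest of the two numbers, but compound 2 lies within the scatter of it, so the two cannot be ordered.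

Compound 3 `Cc1cc(C)c(NC(=O)N(Cc2ccc(-n3cccn3)cc2)C2CCCCCC2)c(C)c1` keeps the core of compound 1 and changes only the substituent on the benzyl ring: 1H-pyrazol-1-yl in place of 4-methylpiperazin-1-yl on an aromatic carbon. For the measured compounds named here, no pair of measured compounds differs in this way, so the size of the step cannot be read from the data; both measured compounds, with different groups on that arm, sit close together, which gives no sign of a strong dependence on this position. The expected step is a 1.5-fold higher number from compound 1 to compound 3 (0.17 log units; within the scatter), a small loss that may not reach beyond the scatter. Compound 3 is thus estimated at 85 nM in this assay, with a range from 30 nM to 250 nM.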

Compound 3, half-maximal inhibitory concentration: 70 nM
Compound 3: the middle estimate sits 1.2-fold (0.08 log units) above what was measured; the measured number falls inside the stated range.
By their numbers in this assay, from the lowest: compounds 1, 3 and 2 (each within the scatter of the next).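

In this assay, for the compounds shown here, the exchange of 4-methylpiperazin-1-yl for 1H-pyrazol-1-yl, on an aromatic carbon para to a large group, gives a 1.2-fold higher number from compound 1 to compound 3 (0.09 log units; within the scatter), the first step at this position that can be read directly. A non-aromatic six-membered ring and an aromatic five-membered ring, which have the same counts of hydrogen-bond donors and acceptors, can therefore stand at this place on the core of compound 1 with no difference that this read-out resolves, something the earlier pair could not show because its members differ in more than one place. Nothing at hand bears on what lies behind a step of this size.

The two groups compared here do not settle whether this position accepts other kinds of group, such as a carboxylic acid, a dimethylamino group or a plain phenyl ring, on the same core. Going by these compounds, it also remains open whether the same exchange would give a similar step on the core of compound 2, or whether the step belongs to the core of compound 1 alone.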